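The compounds below may be only part of what the source reports. "The series", "measured", "known", "first", "only" and "open" are said of these compounds alone.

In a functional assay on U-87MG ATCC cells for antiproliferative activity against U-87 MG (Homo sapiens), read by MTT assay, with a stated time of 48 h (on this read-out higher numbers stand for weaker inhibition and lower numbers for stronger inhibition), compound 2 `COc1ccc(-c2nc(C)c(C(=O)CSc3nc(-c4ccc(OC)cc4)c(C#N)c(=O)[nH]3)s2)cc1` gives 25300 nM and stands within the scatter of compound 1 `COc1ccc(-c2nc(SCC(=O)c3sc(-c4ccccc4)nc3C)[nH]c(=O)c2C#N)cc1` at 48400 nM on the same read-out. Compound 3 `COc1ccc(-c2nc(C)c(C(=O)CSc3nc(-c4ccc(OC)c(OC)c4)c(C#N)c(=O)[nH]3)s2)cc1` differs from compound 2 by methoxy in place of hydrogen on an aromatic carbon in the change from 4-methoxyphenyl to 3,4-dimethoxyphenyl. Within the data shown here, the one measured step of this kind, methoxy in place of hydrogen on an aromatic carbon but on a different ring, is a 1.9-fold lower number from compound 1 to compound 2 (0.28 log units; within the scatter) and offers no sign of a shift. A result within the scatter is therefore expected in this assay with a 1.0-fold lower number from compound 2 to compound 3 (0.01 log units; within the scatter) as the estimated step. Compound 3 is estimated at 25000 nM with an expected range from 11000 nM to 56000 nM for the measurement.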

Compound 3, half-maximal inhibitory concentration: 12500 nM
Estimate against measurement, compound 3: 2.0-fold (0.30 log units) above, within the range that was stated.
By their numbers in this assay, from the lowest: compound 3; then compounds 2 and 1 (each within the scatter of the next).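

In this assay, among these compounds, methoxy in place of hydrogen on this aromatic carbon, ortho to a methoxy group, gives a 2.0-fold lower number from compound 2 to compound 3 (0.31 log units; beyond the scatter) and is the only step that lies beyond the scatter. The position therefore accepts a second methoxy on the ring, and 3,4-dimethoxyphenyl retains activity with a modest gain. Nothing available accounts for this step.

From the compounds shown here alone, whether the gain is specific to methoxy remains open, as a hydroxyl, an amine or a fluorine at this carbon would test this. Also open, going by these compounds, is whether a longer chain, such as ethoxy, is accepted here.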